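Same Methoxy Addition Carried onto a Second Core

The source may report more compounds than this note shows. Statements on the series, on what has been measured and on what is new or still open speak of the compounds shown alone.

Compound 1 `O=C(Nc1ccc(Cl)cc1F)c1ccccc1OCc1ccc(F)cc1F`: in an ADME assay on RAW264.7 cells (Mus musculus) for cytotoxicity, read by MTT assay, with a stated time of 24 h (on this read-out lower numbers stand for higher toxicity in this test and higher numbers for lower toxicity in this test), compound 1 gives > 40000 nM, a limit of the assay.
Compound 2 `COc1ccc(C(=O)Nc2ccc(Cl)cc2F)c(OCc2ccc(F)cc2F)c1`: in this assay compound 2 gives > 40000 nM, likewise a limit of the assay.
Compound 3 `O=C(Nc1ccc(-c2ccc(Cl)cc2Cl)cc1F)c1ccccc1O`: in this assay compound 3 gives 29800 nM.

Compound 3 is the only one of the three that returns a number rather than a limit. The change from compound 1 to compound 2 is methoxy in place of hydrogen on an aromatic carbon, and the step it made is a step that the two limits leave unreadable from compound 1 to compound 2; the size cannot be read, as the limit of > 40000 nM in this assay, at which 2 of the 3 values shown sit, shows. The difference between the core of compound 1 and the core of compound 3 is not broken down here.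

Compound 4 `COc1ccc(C(=O)Nc2ccc(-c3ccc(Cl)cc3Cl)cc2F)c(O)c1` is not yet measured in this assay. It differs from compound 3 by methoxy in place of hydrogen on an aromatic carbon. This is the same kind of change as that from compound 1 to compound 2, but the surroundings differ: in compound 2 the methoxy sits meta to a large group and para to a large group, whereas in compound 4 it sits meta to a hydroxy group and para to a large group.

Among the compounds with values here, since the one measured example of this change, from compound 1 to compound 2, is unreadable, the step from compound 3 to compound 4 in this assay is expected to be small, about a 1.1-fold higher number from compound 3 to compound 4 (0.03 log units; within the scatter). Compound 4 is therefore estimated at 32000 nM, expected to lie between 15000 nM and 60000 nM, close to the value of compound 3 and near the limit of the assay.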

Compound 4, half-maximal cytotoxic concentration: > 40000 nM
Compound 4: only a limit was reported; the forecaster's own chance of this, stated with the estimate: 35%; middle value at least 1.2-fold (0.09 log units) from the limit.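

In this assay, within the data shown here, the methoxy addition on the core of compound 3 gave an at least 1.3-fold higher number from compound 3 to compound 4 (0.12 log units; that floor lies within the scatter), so the only readable example of this change is a floor and not a measured size. It shows that the change did not bring the number down on this core, but it does not show that the change raised the number, since the true step could be no larger than the usual scatter or could be considerably larger. Nor does it show that the change acts alike on the two cores, since the step from compound 1 to compound 2 cannot be read and neither step has an upper end, leaving the two with no sizes to compare: the limit of > 40000 nM in this assay, at which 3 of the 4 values shown sit.

The compounds shown leave open how other groups would behave at the same place on the ring, for instance an amine, a carboxylic acid or a longer chain such as ethoxy in place of the methoxy, and whether any of them would give a number rather than a limit. They also leave open which part of the difference between the core of compound 1 and the core of compound 3 accounts for compound 3 returning a number in this assay.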